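A sulfonyl group replaces acetyl in compound 2

The source may report more compounds than this note shows. Statements on the series, on what has been measured and on what is new or still open speak of the compounds shown alone.

In a functional assay on NCI-H441 cells (Homo sapiens) for antiproliferative activity, with a stated time of 24 h (a lower number here means a stronger inhibitor, a higher number a weaker inhibitor), compound 1 (`O=C(O)CCC(=O)N1C/C(=C\c2ccccc2F)C(=O)/C(=C/c2ccccc2F)C1`) gives 69000 nM and compound 2 (`CC(=O)N1C/C(=C\c2ccccc2F)C(=O)/C(=C/c2ccccc2F)C1`) gives 54000 nM. Going by the values given here, the two values lie within the scatter of each other, so compound 2 cannot be ranked against its only measured neighbour.

Compound 3 (`Cc1ccc(S(=O)(=O)N2C/C(=C\c3ccccc3F)C(=O)/C(=C/c3ccccc3F)C2)cc1`) has yet to be measured in this assay. Its structure departs from that of compound 2 in one place: (4-methylphenyl)sulfonyl in place of acetyl on an amine nitrogen in a ring.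

Among the compounds with values here, only one measured step bears on this change, and only indirectly. It is a 1.3-fold lower number from compound 1 to compound 2 (0.11 log units; within the scatter), a change within the group on that same nitrogen that leaves the carbonyl in place. That step stayed within the scatter, but the new change replaces the whole acetyl, so it offers only weak guidance, and the data give no direction. The expected move is therefore no larger than the scatter, with a slight lean that is a judgement only: a 1.8-fold lower number from compound 2 to compound 3 (0.26 log units; within the scatter). The estimate for compound 3 is 30000 nM, with an expected range from 8000 nM to 90000 nM.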

Compound 3, half-maximal inhibitory concentration: 50000 nM
Compound 3: the middle estimate sits 1.7-fold (0.22 log units) below what was measured, and the stated range covers the measured number.
By their numbers in this assay, from the lowest: compounds 3, 2 and 1 (each within the scatter of the next).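

In this assay the nitrogen of the six-membered non-aromatic ring has now carried three different groups without any separating from the others: the change from acetyl to (4-methylphenyl)sulfonyl gives a 1.1-fold lower number from compound 2 to compound 3 (0.03 log units; within the scatter) and the change from (2-carboxyethyl)carbonyl to (4-methylphenyl)sulfonyl gives a 1.4-fold lower number from compound 1 to compound 3 (0.14 log units; within the scatter) in this comparison. The earlier pair only varied the group beyond a carbonyl that stayed in place, whereas this step removes that carbonyl, brings in a sulfonyl with one six-membered aromatic ring of carbon only, and enlarges the group from 3 to 10 heavy atoms, and still the step stays within the scatter. Nothing available explains why such different groups give values this close.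

The compounds shown leave open whether any group on this nitrogen, such as a free amine, a simple benzyl or a longer chain ending in a carboxylic acid, could produce a step beyond the scatter. They also leave open whether this insensitivity would persist if the shared core itself were altered.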